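Cytotoxicity Ceiling of Cyclopropene Nucleoside Analogues in Fibroblasts

This account rests on a few compounds, and the source may have more. Where it says the series, first, only, none or still open, it means among the compounds named here.

Compound 1 `CN(C)c1nc(N)nc2c1ncn2/C=C1/CC1(CO)CO`: > 300000 nM (a limit)
Compound 2 `Nc1nc(N2CCCC2)c2ncn(/C=C3/CC3(CO)CO)c2n1`: > 300000 nM (a limit)
Compound 3 `CCCCCCOc1nc(N)nc2c1ncn2/C=C1/CC1(CO)CO`: > 200000 nM (a limit)

In an ADME assay on HFF cells (Homo sapiens) for cytotoxicity, with a stated time of 8 days (on this read-out higher numbers stand for lower toxicity in this test and lower numbers for higher toxicity in this test), compound 1 reaches only a limit, > 300000 nM. Compound 2 likewise gives a limit, > 300000 nM. Compound 3 also stops at a limit, > 200000 nM. Two of the values sit at the limit of > 300000 nM in this assay, at which 2 of the 3 values shown sit, and one at the limit of > 200000 nM in this assay, at which 1 of the 3 values shown sits, so compound 1 stands among compounds whose toxicity in this assay is below what the test can report.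

Compound 4 `CCCCNc1nc(N)nc2c1ncn2/C=C1/CC1(CO)CO` differs from compound 1 by butylamino in place of dimethylamino on an aromatic carbon. For the measured compounds named here, the steps a step that the two limits leave unreadable from compound 1 to compound 2 and a step that the two limits leave unreadable from compound 1 to compound 3 bear on this change, and both are unreadable, as is a step that the two limits leave unreadable from compound 2 to compound 3; no measured step in this assay gives a readable size. Compound 4 is therefore expected to remain at the assay ceiling, with a number no higher from compound 1 to compound 4 (the limit leaves the size open) expected to be none beyond the scatter. The estimate for compound 4 is 300000 nM, between 80000 nM and 300000 nM.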

Compound 4, half-maximal cytotoxic concentration: > 300000 nM
Compound 4: a limit, no number; the forecaster's own chance of this, stated with the estimate: 85%; the middle value sits exactly at the limit.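

In this assay compound 4 gives > 300000 nM, a limit, and its steps from compounds 1, 2 and 3 cannot be read. The compounds shown leave open at what concentration, if any, each would become toxic to these cells.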